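The source may hold more compounds than are shown below. What is called first, only, known or untested is meant among the compounds shown, and "the series" means these compounds.

Working notes on the series, read in a functional assay on SK-MEL-28 cells (Homo sapiens) for cytotoxicity, read by CCK-8 assay, with a stated time of 24 h; a lower number here means a stronger inhibitor, a higher number a weaker inhibitor. Compound 1 (`COc1ccccc1Oc1c(N)nc(-c2ccccc2)nc1Cl`) gives 3140 nM and compound 2 (`COc1ccccc1Oc1c(N)nc(-c2cccc(Cl)c2)nc1Cl`) gives 19400 nM. Compound 3 (`COc1ccccc1Oc1c(N)nc(-c2ccccc2)nc1OCCO`) gives > 80000 nM, which is a limit of the assay and not a number.

The next entry is compound 4 (`COc1ccccc1Oc1c(N)nc(-c2ccc(Cl)cc2)nc1OCCO`), reached from compound 3 by chloro in place of hydrogen on an aromatic carbon.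

Going by the values given here, two measured steps bear on this change. The closer one is a 6.2-fold higher number from compound 1 to compound 2 (0.79 log units; beyond the scatter), the same kind of replacement and a modest one, though it was made with the chloro of the shared core still present and with the new chloro placed differently on the ring. The other is an at least 25-fold higher number from compound 1 to compound 3 (1.40 log units; beyond the scatter), a large step that compound 3 already carries. Among the compounds with values here, no measured chloro step lowers the number.

Within the data shown here, a modest move toward a higher number in this assay is therefore expected, because a 6.2-fold higher number from compound 1 to compound 2 (0.79 log units; beyond the scatter) is the only guide of its kind. The expected change is a step that the limit leaves unreadable from compound 3 to compound 4, and a reading at the limit is the likeliest outcome. The estimated value for compound 4 is 100000 nM, with an expected range of 35000 nM to 300000 nM.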

Compound 4, half-maximal inhibitory concentration: > 80000 nM
Compound 4: only a limit was reported; the forecaster's own chance of this, stated with the estimate: 70%; the middle value does not contradict the limit.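

Compound 3 and compound 4 both stand as limits of this assay and not as numbers, so the step between them, phenyl to 4-chlorophenyl, cannot be read: the limit of > 80000 nM in this assay, at which 2 of the 4 values shown sit.

The compounds shown leave open whether 4-chlorophenyl in place of phenyl changes the reading at all when 2-hydroxyethoxy stands in place of the chloro of compound 1.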